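The source may hold more compounds than are shown below. What is called first, only, known or untested is meant among the compounds shown, and "the series" means these compounds.

Working notes on the series. One core is shared by compound 1 `CCn1c(C(=O)NCC#N)ccc1C(CC)(CC)c1ccc(OCCC(O)(CC)CC)c(C)c1`, compound 2 `CCn1c(C(=O)NCCN)ccc1C(CC)(CC)c1ccc(OCCC(O)(CC)CC)c(C)c1` and compound 3 `CCn1c(C(=O)Nc2cccc(C(F)(F)F)c2)ccc1C(CC)(CC)c1ccc(OCCC(O)(CC)CC)c(C)c1`; they differ only on the amide-type nitrogen. In an ADME assay on L02 cells (Homo sapiens) for antiproliferative activity, read by MTT assay, with a stated time of 48 h (a lower number here means a stronger inhibitor, a higher number a weaker inhibitor), compound 1 reports only the limit > 50000 nM. Compound 2 gives 2940 nM in this assay. Compound 3 likewise stops at the limit > 50000 nM in this assay, so compound 3 sits at the limit of > 50000 nM in this assay, at which 2 of the 3 values shown sit. The measured steps read an at least 17-fold lower number from compound 1 to compound 2 (1.23 log units; beyond the scatter), an at least 17-fold higher number from compound 2 to compound 3 (1.23 log units; beyond the scatter) and a step that the two limits leave unreadable from compound 1 to compound 3.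

Compound 4 `CCn1c(C(=O)NC(CC(=O)O)C(=O)OC)ccc1C(CC)(CC)c1ccc(OCCC(O)(CC)CC)c(C)c1` carries the change (a group of 9 heavy atoms (5 carbon, 4 oxygen; no ring) in place of a group of 10 heavy atoms (7 carbon, 3 fluorine; one six-membered aromatic ring of carbon only), on an amide-type nitrogen). Going by the values given here, no measured step covers this change; only the aminoethyl compound 2 moved off the limit. Compound 4 is therefore expected to stay near the limit, a number no higher from compound 3 to compound 4 (the limit leaves the size open). Compound 4 is estimated at 50000 nM, within 10000 nM to 200000 nM, most probably reported as a limit again.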

Compound 4, half-maximal inhibitory concentration: 7590 nM
Compound 4: middle estimate off by 6.6-fold (0.82 log units), on the high side; measured number outside the range, below it.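

A basic amine is not needed on the amide-type nitrogen to come off the limit: the acid-ester chain, with no net charge as counted, also gives a measurable number, with an at least 6.5-fold lower number from compound 3 to compound 4 (0.81 log units; beyond the scatter) and an at least 6.5-fold lower number from compound 1 to compound 4 (0.81 log units; beyond the scatter). The 2-aminoethyl group still holds the lower number, with a 2.6-fold higher number from compound 2 to compound 4 (0.41 log units; beyond the scatter). Compound 1 and compound 3 remain limits of the assay: the limit of > 50000 nM in this assay, at which 2 of the 4 values shown sit.

The compounds shown leave open whether the carboxylic acid or the methyl ester of the new group goes with this change. A simple chain carrying only the carboxylic acid, or a longer amine chain, would bear on that.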